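This account rests on a few compounds, and the source may have more. Where it says the series, first, only, none or still open, it means among the compounds named here.

Working notes on the series.

Compound 1 `CC(Cn1cc[n+](C)c1/C=N/O)NS(=O)(=O)C(F)(F)F` and compound 2 `CCC(Cn1cc[n+](C)c1/C=N/O)NS(=O)(=O)C(F)(F)F` share one core; compound 3 `CC(CS(C)(=O)=O)OCn1cc[n+](C)c1/C=N/O` carries a different one. In a physicochemical assay for lipophilicity (on this read-out lower numbers stand for lower lipophilicity and higher numbers for higher lipophilicity), compound 1 gives -0.82. In this assay compound 2 gives -0.42. In this assay compound 3 gives -2.66, the lowest of the three measured numbers. Going by the values given here, the single difference between compound 1 and compound 2 is methyl in place of hydrogen on a saturated chain carbon, two bonds along the chain from a sulfonamide nitrogen and the measured step is a number 0.40 log units higher from compound 1 to compound 2 (beyond the scatter). The difference between the two cores, that of compound 1 and that of compound 3, is not broken down here.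

Compound 4 `CCS(=O)(=O)CC(C)OCn1cc[n+](C)c1/C=N/O` has not yet been measured. It differs from compound 3 by methyl in place of hydrogen on a saturated chain carbon bound to a sulfonyl sulfur. Among the compounds with values here, this is the same kind of change as the one from compound 1 to compound 2, but not the same: in compound 2 the methyl sits on a saturated chain carbon, two bonds along the chain from a sulfonamide nitrogen, whereas in compound 4 it sits on a saturated chain carbon bound to a sulfonyl sulfur, and the cores differ as well.

Within the data shown here, the expectation for compound 4 rests on the one measured step, since compound 2 rose over compound 1 by a number 0.40 log units higher from compound 1 to compound 2 (beyond the scatter). A step of similar size is expected, namely a number 0.36 log units higher from compound 3 to compound 4 (beyond the scatter), set a little more cautiously for the changed surroundings. Compound 4 is therefore estimated at -2.3, with a range from -2.7 to -1.9.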

Compound 4, distribution coefficient: -2.7
The estimate for compound 4 lay 0.40 log units above the measured number; low and high end bracket the measured number.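

In this assay, methyl in place of hydrogen on a saturated chain carbon bound to a sulfonyl sulfur gives a number 0.04 log units lower from compound 3 to compound 4 (within the scatter), so compound 3 and compound 4 stand within the scatter of each other, whereas the related methyl change on the core of compound 1 gave a number 0.40 log units higher from compound 1 to compound 2 (beyond the scatter). In this one pair, then, the step beyond the scatter seen on the core of compound 1 does not carry over to the core of compound 3; what it does not show is whether the core or the place of the methyl accounts for this, as the two pairs differ in both, and one pair on each core supports no rule for the series. Nothing measured here bears on why the two steps differ.

The compounds shown leave open how a longer chain, such as propylsulfonyl in place of ethylsulfonyl, would read in this assay on the core of compound 3. They also leave open whether an amine or a carboxylic acid in place of the methyl would give a step beyond the scatter on either core.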